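A few compounds are considered here, and "the series" means these few. Any claim that something is new, unique, unknown or untested is made for them only; others in the source may bear on it.

Three compounds have been measured in an ADME assay for permeability; on this read-out lower numbers stand for lower permeability and higher numbers for higher permeability:

- compound 1, `CNC(=O)c1cc(C(=O)N[C@H]2CC[C@H](O)CC2)c([C@@H](C)c2cccc(C)c2)o1`, gives 85 nm/s
- compound 2, `CNC(=O)c1cc(C(=O)NC2CC2)cn(Cc2cccc3[nH]ccc23)c1=O`, gives 178 nm/s
- compound 3, `CNC(=O)c1cc(C(=O)NC2CC2)cn([C@H](C)c2ccccc2)c1=O`, gives 160 nm/s

Compound 1 has the lowest of the three numbers. Its gap to compound 3 is within the usual scatter of repeated measurements, so those two cannot be told apart; its gap to compound 2 is beyond the scatter, so compound 2 does show higher permeability than compound 1. Among the compounds with values here, compounds 2 and 3 share a different core from compound 1 and are not single-point neighbours of it, so no single structural step between measured compounds is available.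

Compound 4, `CNC(=O)c1cc(C(=O)N[C@H]2CC[C@H](O)CC2)c([C@@H](C)c2ccccc2)o1`, is not yet measured. It differs from compound 1 in one place only: hydrogen in place of methyl on an aromatic carbon. The rest of the molecule, including the hydroxycyclohexyl amide and the shared core, is unchanged.

Within the data shown here, with no measured step to lean on, a change this small is expected to move this assay little: the step of a 1.1-fold lower number from compound 1 to compound 4 (0.05 log units; within the scatter) is expected to fall within the scatter, with no clear direction. Compound 4 is therefore expected to give about 75 nm/s, within a range from 40 nm/s to 140 nm/s.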

Compound 4, apparent permeability in the ADME assay: 42 nm/s
The estimate for compound 4 lay 1.8-fold (0.25 log units) above the measured number; the measured number falls inside the stated range.
By their numbers in the ADME assay, from the lowest: compound 4; then compounds 1, 3 and 2 (each within the scatter of the next, the first and the last beyond it).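

Within the data shown here, in the ADME assay, going from 3-methylphenyl to phenyl gives a 2.0-fold lower number from compound 1 to compound 4 (0.31 log units; beyond the scatter); this is the first comparison here in which only one place changes, and it shows that swapping a single methyl for hydrogen on this aromatic carbon can move the read-out modestly but beyond the scatter, which the earlier compounds, with their different cores, could not reveal. In a physicochemical assay for solubility, read by HPLC, in simulated intestinal fluid, with a stated time of 16 h, at pH 6.5 (a lower number here means a less soluble compound, a higher number a more soluble compound), compound 4 gives 827 ug/mL, a number that can be read as it stands. In the physicochemical assay compound 1 gives > 1000 ug/mL, which is a limit of the assay and not a number, so the size of the step between these two compounds cannot be read: the limit of > 1000 ug/mL in the physicochemical assay, at which 1 of the 2 values shown sits.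

On these data alone, what a chlorine atom, a methoxy group or an amine on the same aromatic carbon would do to either read-out stays open, so one step cannot yet show whether size or some other feature of the group matters here. As far as these compounds go, it also stays open whether a methyl group added to the phenyl ring of compound 3, on its different core, would shift the number in the same direction.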